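The source may report more compounds than this note shows. Statements on the series, on what has been measured and on what is new or still open speak of the compounds shown alone.

Measured in an ADME assay for permeability, using PAMPA, at pH 7.4; on this read-out lower numbers stand for lower permeability and higher numbers for higher permeability:
Compound 1 `O=C(Nc1ccc(F)c(-c2nc3ccccc3s2)c1)c1cc([N+](=O)[O-])ccc1Cl`: 17 10^-6 cm/s
Compound 2 `O=C(Nc1cccc(-c2nc3ccccc3s2)c1)c1cc([N+](=O)[O-])ccc1Cl`: 12 10^-6 cm/s
Compound 3 `O=C(Nc1cccc(-c2nc3ccccc3o2)c1)c1cc([N+](=O)[O-])ccc1Cl`: 45 10^-6 cm/s

Compound 2 cannot be separated from compound 1 on these numbers, while compound 3 reads higher than both. Compound 4 `COc1ccc(NC(=O)c2cc([N+](=O)[O-])ccc2Cl)cc1-c1nc2ccccc2s1` differs from compound 2 by one change: methoxy in place of hydrogen on an aromatic carbon. The closest guide is a 1.4-fold lower number from compound 1 to compound 2 (0.15 log units; within the scatter), where fluoro on that same carbon gives way to hydrogen. The other step, a 3.8-fold higher number from compound 2 to compound 3 (0.57 log units; beyond the scatter), concerns a different part of the molecule and shows only that this read-out can move. Methoxy is not fluoro, so the guide is loose. The estimated step is a 1.2-fold higher number from compound 2 to compound 4 (0.07 log units; within the scatter), nothing beyond the scatter in this assay. For compound 4 the expected value is 14 10^-6 cm/s, with an estimated range of 6 10^-6 cm/s to 32 10^-6 cm/s.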

Compound 4, apparent permeability: "below limit of detection" (no number reported)
Compound 4 has no reported number here, and the estimate cannot be compared.
By their numbers in this assay, from the lowest: compounds 2 and 1 (each within the scatter of the next); then compound 3.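

In this assay, for the compounds shown here, compound 4 is recorded only as below the limit of detection, so no step from compound 2 to compound 4 can be read. From the compounds shown here alone, whether and how far methoxy in place of hydrogen shifts the number stays open. No evidence on hand explains this result.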